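This account rests on a few compounds, and the source may have more. Where it says the series, first, only, none or still open, it means among the compounds named here.

Measured so far:
compound 1, `COc1ccc(OCCOc2ccc3[nH]c(=O)n(C(C)C)c3c2)cc1`: 15.5%
compound 2, `CCn1c(=O)[nH]c2ccc(OCCOc3ccc(Cl)cc3)cc21`: 7.24%

Both numbers come from an assay on cells for inhibition of Amine oxidase [flavin-containing] B (Homo sapiens), read by fluorescence, with stated times of 30 min and 15 min, tested at 1 uM; a lower number here means less inhibition, a higher number more inhibition at the concentration tested (going by the name of the read-out). At the tested concentration compound 2 gives 7.24% and compound 1 gives 15.5%; the gap between them is within the usual scatter of this read-out, so the two cannot be told apart, and both show little inhibition. Going by the values given here, no pair of measured compounds differs in only one place, so nothing yet fixes the size of a single change.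

Compound 3, `CC(C)n1c(=O)[nH]c2ccc(OCCOc3ccc(Cl)cc3)cc21`, has not been measured in this assay. Relative to compound 2 the difference is methyl in place of hydrogen on a saturated chain carbon bound to an aromatic nitrogen and a saturated chain carbon. Compound 1 also carries an isopropyl group, but it differs from compound 3 in the other aryl part as well, so it offers no clean comparison. Among the compounds with values here, with no measured step to lean on, no shift beyond the scatter is expected in this assay. Compound 3 is therefore estimated at about 12%, between 0% and 28%. The expected step of a number 4.8 percentage points higher from compound 2 to compound 3 (within the scatter) lies within the scatter.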

Compound 3, a percentage reported as inhibition, at one concentration (the size of the read-out at that concentration, not a potency): 18.2%
Estimate against measurement, compound 3: 6.2 percentage points below; the measured number falls inside the stated range.
By their numbers in this assay, from the lowest: compounds 2, 1 and 3 (each within the scatter of the next, the first and the last beyond it).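

Going by these compounds alone, the change from ethyl to isopropyl is the first single change read at this position, and in this assay it gives a number 11 percentage points higher from compound 2 to compound 3 (beyond the scatter); one added methyl on this saturated chain carbon is thus enough to move the read-out past the scatter, though only modestly. With the isopropyl group held, chloro in place of methoxy on an aromatic carbon gives a number 2.7 percentage points higher from compound 1 to compound 3 (within the scatter), so that aryl change cannot be separated from no change here. No measured evidence bears on the reason for either step.

On these data alone, whether a tert-butyl group or a longer chain at this position would extend the step remains open, as does whether an amine on that chain would keep it. Also open, as far as these compounds go, is whether the methyl step holds with methoxy in place of chloro.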